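Methoxy Addition on a Chalcone Series Measured in Liver Cells

This account rests on a few compounds, and the source may have more. Where it says the series, first, only, none or still open, it means among the compounds named here.

Compound 1, `COc1cc(O)cc(O)c1C(=O)/C=C/c1ccc(O)cc1`, gives in a functional assay on HepG2 cells (Homo sapiens) for inhibition, read by MTT assay, with a stated time of 72 h (on this read-out lower numbers stand for stronger inhibition and higher numbers for weaker inhibition), a value of 40200 nM.
Compound 2, `COc1cc(/C=C/C(=O)c2c(O)cc(O)cc2OC)ccc1O`, gives in this assay only a limit of the assay, > 50000 nM.
Compound 3, `COc1cc(/C=C/C(=O)c2c(O)cc(O)cc2OC)cc(OC)c1`, gives in this assay a value of 17600 nM.

The three measured compounds share a common skeleton and differ on one ring. How the core of compound 1 and the core of compound 3 differ is not broken down here. Compound 3 sits lowest of the two numbered values; its nearest neighbour is compound 1, which lies beyond the usual scatter above it.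

Compound 4, `COc1cc(/C=C/C(=O)c2c(O)cc(O)cc2OC)cc(OC)c1OC`, has not yet been measured in this assay. It differs from compound 3 by methoxy in place of hydrogen on an aromatic carbon.

The same kind of change has already been made once, from compound 1 to compound 2: methoxy in place of hydrogen on an aromatic carbon. There it gave an at least 1.2-fold higher number from compound 1 to compound 2 (0.09 log units; that floor lies within the scatter), and the floor of that step rests on (the limit of > 50000 nM in this assay, at which 1 of the 3 values shown sits). The surroundings of the new group are not the same in the two cases: in the earlier one it sits ortho to a hydroxy group and meta to a large group, in the present one ortho to two methoxy groups and para to a large group.

From compound 3 to compound 4 a step of about a 1.3-fold higher number from compound 3 to compound 4 (0.10 log units; within the scatter) is expected, resting on the measured move from compound 1 to compound 2. For compound 4 the estimate in this assay is 22000 nM, expected to fall between 8000 nM and 50000 nM.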

Compound 4, half-maximal inhibitory concentration: 20400 nM
For compound 4 the middle estimate is 1.1-fold (0.03 log units) above the measured one, and the stated range covers the measured number.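

In this assay, methoxy in place of hydrogen on an aromatic carbon gives a 1.2-fold higher number from compound 3 to compound 4 (0.06 log units; within the scatter), so on this core the effect of the added group cannot be told apart from the usual scatter of repeated measurements. Going by these compounds, this result alone does not show that the change carries over from one core to another with the same size, as the earlier step gives only a floor and the comparison stays open: the same change on two cores in this assay, an at least 1.2-fold higher number (0.09 log units; that floor lies within the scatter) from compound 1 to compound 2 and a 1.2-fold higher number (0.06 log units; within the scatter) from compound 3 to compound 4; the limit leaves it open whether they differ Compound 2 gives > 50000 nM, which is a limit of the assay and not a number, so the true size of the earlier step is unknown, and two pairs are in any case too few to set a rule for the whole series.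

Both steps bring in the same group, so the compounds shown leave open what a different group would do at the place ortho to two methoxy groups and para to a large group, for example an amine, a carboxylic acid or a longer chain. They also leave open whether the small step seen on this core would appear on other cores in the series.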